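A few compounds are considered here, and "the series" means these few. Any claim that something is new, unique, unknown or untested is made for them only; others in the source may bear on it.

Two compounds have so far been measured in a functional assay on HepG2 cells (Homo sapiens) for antiproliferative activity, read by MTT assay, with a stated time of 72 h; a higher number here means a weaker inhibitor, a lower number a stronger inhibitor:

compound 1, `Cc1nn(C)c(Oc2ccc(F)cc2)c1/C=N\CCCCCCOc1cc2oc(=O)cc(C)c2cc1Cl`, gives 12500 nM in this assay;
compound 2, `Cc1nn(C)c(Oc2ccc(F)cc2F)c1/C=N\CCCCCCOc1cc2oc(=O)cc(C)c2cc1Cl`, gives in this assay only the limit > 25000 nM, not a number.

Going by the values given here, compound 2 therefore stands at the edge of what this assay reports: the one step that leads to it, an at least 2.0-fold higher number from compound 1 to compound 2 (0.30 log units; that floor lies within the scatter), carries only a floor, and that floor lies within the scatter, because compound 2 sits at the limit of > 25000 nM in this assay, at which 1 of the 2 values shown sits.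

Compound 3, `Cc1nn(C)c(Oc2ccc(Cl)cc2)c1/C=N\CCCCCCOc1cc2oc(=O)cc(C)c2cc1Cl`, has not yet been measured. It differs from compound 2 by 4-chlorophenyl in place of 2,4-difluorophenyl on an oxygen on an aromatic ring. Among the compounds with values here, no measured step covers a chlorine in place of a fluorine on a phenyl ring attached to that oxygen; the only related step is an at least 2.0-fold higher number from compound 1 to compound 2 (0.30 log units; that floor lies within the scatter), which put a fluorine in place of a hydrogen. Compound 3 gives that fluorine up again, so the step expected in this assay, an at least 2.0-fold lower number from compound 2 to compound 3 (0.30 log units; that floor lies within the scatter), points towards a lower number, of a size that the floor alone cannot fix. Compound 3 is thus estimated at 12500 nM, within a range from 5000 nM to 30000 nM.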

Compound 3, half-maximal inhibitory concentration: 2960 nM
Estimate against measurement, compound 3: 4.2-fold (0.63 log units) above; measured number outside the range, below it.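

In this assay, going by these compounds alone, chloro in place of fluoro on an aromatic carbon of the phenyl ring gives a 4.2-fold lower number from compound 1 to compound 3 (0.63 log units; beyond the scatter), the first step at this position with a measured size beyond the scatter, and it shows that one halogen exchange on this ring is enough to change the antiproliferative reading. The change from 2,4-difluorophenyl to 4-chlorophenyl on the oxygen gives an at least 8.4-fold lower number from compound 2 to compound 3 (0.92 log units; beyond the scatter), which also lies beyond the scatter, whereas the earlier step on this ring carried only a floor within it. This larger step is itself a floor and not a full size, because compound 2 sits at a limit of the assay: the limit of > 25000 nM in this assay, at which 1 of the 3 values shown sits.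

On these data alone, it remains open whether a bromine or a methyl in place of that chlorine would lower the number further or raise it again, and so whether the gain belongs to chlorine alone. Also open, as far as these compounds go, is how a longer chain between the imine nitrogen and the oxygen on the far ring would act together with the 4-chlorophenyl group.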